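The source may report more compounds than this note shows. Statements on the series, on what has been measured and on what is new or still open speak of the compounds shown alone.

Working notes on a tetrazole thioacetohydrazone series, read in an ADME assay on NIH3T3 cells (Mus musculus) for cytotoxicity, read by XTT assay, with a stated time of 24 h; a higher number here means a weaker inhibitor, a lower number a stronger inhibitor.

Compound 1 `Cn1nnnc1SCC(=O)N/N=C/c1ccccc1F` gives 2000000 nM. Compound 2 `Cn1nnnc1SCC(=O)N/N=C/c1cccc(F)c1`, in which the same atoms are joined differently, gives 6320000 nM; how the two cores differ is not broken down here. Compound 3 `Cn1nnnc1SCC(=O)N/N=C/c1ccccc1Cl` gives only a limit of the assay, > 10000000 nM, the limit (the limit of > 10000000 nM in this assay, at which 1 of the 3 values shown sits).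

Going by the values given here, the single measured step is chloro in place of fluoro on an aromatic carbon, and it moves the number an at least 5.0-fold higher number from compound 1 to compound 3 (0.69 log units; beyond the scatter).

Compound 4 `Cn1nnnc1SCC(=O)N/N=C/c1cccc(Cl)c1` is not yet measured. It differs from compound 2 by chloro in place of fluoro on an aromatic carbon. Among the compounds with values here, this is the same kind of change as the one from compound 1 to compound 3, not the same change: there the group sits ortho to a large group, here meta to a large group.

Given that compound 2 already sits higher than compound 1 and the step of an at least 5.0-fold higher number from compound 1 to compound 3 (0.69 log units; beyond the scatter) reached the limit of the assay, a step of a 2.4-fold higher number from compound 2 to compound 4 (0.38 log units; beyond the scatter) is expected, and compound 4 may well return only a limit. Compound 4 is estimated at 15000000 nM, between 5000000 nM and 50000000 nM.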

Compound 4, half-maximal inhibitory concentration: 7500000 nM
Beside the measured number, compound 4's estimate is 2.0-fold (0.30 log units) above it; the range from low to high includes it.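

In this assay chloro in place of fluoro on an aromatic carbon does not carry over as a single step from the core of compound 1 to the core of compound 2: the same change on two cores in this assay, an at least 5.0-fold higher number (0.69 log units; beyond the scatter) from compound 1 to compound 3 and a 1.2-fold higher number (0.07 log units; within the scatter) from compound 2 to compound 4, at least 4.2-fold (0.62 log units) apart, beyond the scatter of two such steps. The new step is a 1.2-fold higher number from compound 2 to compound 4 (0.07 log units; within the scatter) and stays within the scatter, so with the group meta to a large group this exchange shows no measurable change. Compound 3 gives > 10000000 nM as a limit of the assay and not a number, so the earlier step has only a lower bound, and two pairs do not show what lies behind the difference or whether it would hold on further cores.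

The compounds shown leave open how the series reads when the aromatic ring carries something other than a single halogen, such as a methoxy group, a nitrile or an amine. Also open, going by these compounds, is whether a carboxylic acid or a longer chain elsewhere on the shared core would read differently in this assay.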